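This account rests on a few compounds, and the source may have more. Where it says the series, first, only, none or still open, it means among the compounds named here.

In a functional assay on Jurkat cells (Homo sapiens) for inhibition (on this read-out lower numbers stand for stronger inhibition and higher numbers for weaker inhibition), the measured compounds stand as follows:

compound 1 `CC(C)[C@H](NC(=O)COc1cccc2ccccc12)C(=O)N[C@@H](CC(=O)O)C(=O)CSc1nc(-c2ccccc2)no1` gives 102000 nM;
compound 2 `CC(C)[C@H](NC(=O)COc1cccc2ccccc12)C(=O)N[C@@H](CC(=O)O)C(=O)CSc1nnnn1C` is reported only as a limit of the assay, > 200000 nM;
compound 3 `CC(C)[C@H](NC(=O)COc1cccc2ccccc12)C(=O)N[C@@H](CC(=O)O)C(=O)COc1ccccn1` is likewise reported only as a limit, > 200000 nM.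

Compound 1 is the only one of the three with a number; the other two sit at the limit of > 200000 nM in this assay, at which 2 of the 3 values shown sit. Compound 4 `CC(C)[C@H](NC(=O)COc1cccc2ccccc12)C(=O)N[C@@H](CC(=O)O)C(=O)COc1cc2ccccc2cn1` differs from compound 1 in one place: (isoquinolin-3-yl)oxy in place of (3-phenyl-1,2,4-oxadiazol-5-yl)sulfanyl on a saturated chain carbon bound to a carbonyl carbon. The step that bears most on this change is the one with (pyridin-2-yl)oxy, where this assay shows an at least 1.9-fold higher number from compound 1 to compound 3 (0.29 log units; that floor lies within the scatter). The replacement of the sulfur-linked group by a methyltetrazole gave an at least 1.9-fold higher number from compound 1 to compound 2 (0.29 log units; that floor lies within the scatter), again reaching only the limit. Both exchanges point the same way, toward a higher number, though each floor is within the scatter. An (isoquinolin-3-yl)oxy group is expected to behave like the pyridinyloxy, so for compound 4 the step of a 2.0-fold higher number from compound 1 to compound 4 (0.29 log units; within the scatter) is expected, and its value is estimated at 200000 nM, within 90000 nM to 450000 nM, with a fair chance that the assay reports only a limit.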

Compound 4, half-maximal inhibitory concentration: > 200000 nM
Compound 4 gave a limit, no number; the forecaster's own chance of this, stated with the estimate: 55%; the middle value lies on the limit itself.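

In this assay, the (isoquinolin-3-yl)oxy group, which carries two aromatic rings as the group in compound 1 does, gives an at least 1.9-fold higher number from compound 1 to compound 4 (0.29 log units; that floor lies within the scatter), so two aromatic rings on this saturated chain carbon did not by themselves yield a number. The steps from compound 2 and from compound 3 to compound 4 cannot be read, since both ends of each are limits. Compound 1 remains the only compound with a number, and compound 4 is reported only as a limit: the limit of > 200000 nM in this assay, at which 3 of the 4 values shown sit.

The compounds shown leave open whether the sulfur link or the 3-phenyl-1,2,4-oxadiazol-5-yl ring accounts for the number of compound 1, since none pairs one ring with both links. They also leave open whether an amine or a carboxylic acid on the phenyl ring of compound 1 would shift its value.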